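Flipping One Stereocentre in Compound 2

This account rests on a few compounds, and the source may have more. Where it says the series, first, only, none or still open, it means among the compounds named here.

Measured in a functional assay on NALM-6 cells (Homo sapiens) for cytotoxicity, read by MTT assay, with a stated time of 48 h; a lower number here means a stronger inhibitor, a higher number a weaker inhibitor:
- compound 1 `C=C1C(=O)O[C@@H](C)[C@@H]1c1ccc(Br)cc1`: 1100 nM
- compound 2 `C=C1C(=O)O[C@H](C)[C@@H]1c1ccc(C)cc1`: 5970 nM

Going by the values given here, of these two numbers, the one for compound 2 is the higher, making it the weaker inhibitor, and the gap to compound 1 lies beyond the usual scatter. Compound 3 `C=C1C(=O)O[C@@H](C)[C@@H]1c1ccc(C)cc1` differs from compound 2 in one way: the two compounds have the same atoms and bonds and differ only in configuration as drawn: 1 of 2 stereo elements differ; a stereocentre at a saturated ring carbon is drawn R in compound 2 and S in compound 3. Among the compounds with values here, no measured pair here shows what such a change does, so any forecast is uncertain. The expected change is a 2.0-fold lower number from compound 2 to compound 3 (0.30 log units; within the scatter), a modest move toward a lower number in this assay. For compound 3 the estimate is 3000 nM, with an expected range of 1000 nM to 8000 nM.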

Compound 3, half-maximal inhibitory concentration: 4390 nM
The estimate for compound 3 lay 1.5-fold (0.17 log units) below the measured number; the measured number falls inside the stated range.
By their numbers in this assay, from the lowest: compound 1; then compounds 3 and 2 (each within the scatter of the next).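

In this assay, flipping this stereocentre gives a 1.4-fold lower number from compound 2 to compound 3 (0.13 log units; within the scatter), so the two compounds cannot be told apart, and the comparison isolates a single change: the fact that compounds 2 and 3 differ only in the configuration as drawn. Going by these compounds alone, the first direct reading at the aromatic carbon, methyl in place of bromo, gives a 4.0-fold higher number from compound 1 to compound 3 (0.60 log units; beyond the scatter), a step that does lie beyond the scatter. In this small set, then, the aromatic substituent moves the number more than this stereocentre does. Still open, going by these compounds, is whether flipping the other stereocentre matters, and what an amine or a carboxylic acid on that aromatic carbon would do.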